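The compounds below may be only part of what the source reports. "The series", "measured", "known", "first", "only" and "open" are said of these compounds alone.

Working notes on the series. Three compounds share a core; compound 1 `CC(=O)N1CCC(N(C)c2nc3ccc(NC(=O)CCc4ccc(C(F)(F)F)cc4)cc3[nH]2)C1` carries an acetylpyrrolidinyl group on the methylamino nitrogen, compound 2 `CC(C)N(C)c1nc2ccc(NC(=O)CCc3ccc(C(F)(F)F)cc3)cc2[nH]1` an isopropyl group there, and compound 3 `CN(c1nc2ccc(NC(=O)CCc3ccc(C(F)(F)F)cc3)cc2[nH]1)C1CCCC1` a cyclopentyl group. Among the measured compounds shown here, in a functional assay on CHO-K1 cells for antagonist activity at melanin-concentrating hormone receptor 1 (Homo sapiens), read by FLIPR and calcium flux (a lower number here means a stronger inhibitor, a higher number a weaker inhibitor), compound 2 gives 21 nM; for compound 1 the entry in this assay reads "not determined" (no result reported), so compound 2 holds the only number in the set and there is nothing to rank it against.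

The step from compound 2 to compound 3 is cyclopentyl in place of isopropyl on a nitrogen on an aromatic ring. For the measured compounds named here, no measured pair with the same change exists, so the size of the step in this assay cannot be read from the data. Going from a branched chain of three carbons to a ring of five carbons at this amine is expected to move the number little, if at all, beyond the scatter; the step from compound 2 to compound 3 is estimated at a 1.4-fold lower number from compound 2 to compound 3 (0.15 log units; within the scatter), with a slight lean toward a lower number. Compound 3 is therefore expected to give about 15 nM in this assay, estimated within 5 nM to 50 nM.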

Compound 3, half-maximal inhibitory concentration: 22 nM
For compound 3 the middle estimate is 1.5-fold (0.17 log units) below the measured one, and the stated range covers the measured number.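

In this assay, cyclopentyl in place of isopropyl on a nitrogen on an aromatic ring gives a 1.0-fold higher number from compound 2 to compound 3 (0.02 log units; within the scatter), the only measured step at this position in the compounds shown. For this pair, the nitrogen carries a five-membered carbon ring and a branched chain of three carbons with the same reading, so the added carbons and the ring leave no mark that can be told from the scatter. Nothing on hand accounts for this result.

Going by these compounds, whether the same holds for other groups on this nitrogen stays open: a cyclohexyl ring, a piperidine ring with its amine, or a cyclopentyl ring bearing a carboxylic acid could each read differently in this assay. Also open, on these data alone, is whether the methyl group on the same nitrogen can give way to a longer chain, and whether one pair of closely matched carbon groups says anything about the position as a whole.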